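Notes on three measured analogues and one pending

The source may report more compounds than this note shows. Statements on the series, on what has been measured and on what is new or still open speak of the compounds shown alone.

Measured so far:
Compound 1, `Cc1ccc2c(c1)C1(C(=O)N2Cc2ccccc2)C(C#N)=C(N)Oc2cc3oc(-c4ccccc4)cc(=O)c3c(O)c21`: in a functional assay on PC-3 cells (Homo sapiens) for antiproliferative activity, read by MTT assay, with a stated time of 48 h (a lower number here means a stronger inhibitor, a higher number a weaker inhibitor), compound 1 gives > 50000 nM, which is a limit of the assay rather than a number.
Compound 2, `Cc1cccc2c1N(Cc1ccccc1)C(=O)C21C(C#N)=C(N)Oc2cc3oc(-c4ccccc4)cc(=O)c3c(O)c21`: in this assay compound 2 gives > 50000 nM, again a limit.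
Compound 3, `CCN1C(=O)C2(C(C#N)=C(N)Oc3cc4oc(-c5ccccc5)cc(=O)c4c(O)c32)c2cccc(C)c21`: in this assay compound 3 gives > 50000 nM, also a limit.

All three values sit at the same boundary, (the limit of > 50000 nM in this assay, at which 3 of the 3 values shown sit), so no ranking among them is possible. Compound 1 and compound 2 share the same atoms joined differently; the difference between the two cores is not broken down here. Compound 2 and compound 3 differ by methyl in place of phenyl on a saturated chain carbon bound to an amide-type nitrogen in a ring, and the step that the two limits leave unreadable from compound 2 to compound 3 cannot be sized, since both ends are limits.

Compound 4, `CCN1C(=O)C2(C(C#N)=C(N)Oc3cc4oc(-c5ccccc5)cc(=O)c4c(O)c32)c2cc(C)ccc21`, is not yet measured. It differs from compound 1 by methyl in place of phenyl on a saturated chain carbon bound to an amide-type nitrogen in a ring; the place lines match word for word, so this is the same change as that from compound 2 to compound 3. Because compound 2 and compound 3 both sit at the limit of > 50000 nM in this assay, at which 3 of the 3 values shown sit, compound 4 is expected to remain at the limit as well. The expected step is a step that the limit leaves unreadable from compound 1 to compound 4. The estimate for compound 4 is 80000 nM, with a range from 30000 nM to 300000 nM.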

Compound 4, half-maximal inhibitory concentration: > 50000 nM
Compound 4: no number, only a limit; the forecaster's own chance of this, stated with the estimate: 85%; the middle value lies beyond the limit too.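

In this assay compound 4 gives > 50000 nM, which is a limit of the assay and not a number. No step can be read between compound 1 and compound 4, since both ends are limits: the limit of > 50000 nM in this assay, at which 4 of the 4 values shown sit.

As far as these compounds go, how benzyl compares with ethyl on either core stays open, with no number among compound 1, compound 2, compound 3 and compound 4 in this assay.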